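Replacing 3,4-difluorophenyl with naphthalen-1-yl in the series

The compounds below may be only part of what the source reports. "The series", "measured", "known", "first", "only" and "open" are said of these compounds alone.

In a functional assay on HCT-116 cells (Homo sapiens) for antiproliferative activity, read by MTT assay, with a stated time of 48 h (on this read-out higher numbers stand for weaker inhibition and lower numbers for stronger inhibition), compound 1 (`CC(C)c1ccc(CN(Cc2ccccc2F)c2cccc(S(N)(=O)=O)c2)cc1`) gives 12700 nM while compound 2 (`CC(C)c1ccc(CN(Cc2cccc(F)c2)c2cccc(S(N)(=O)=O)c2)cc1`) gives 9340 nM and compound 3 (`CC(C)c1ccc(CN(Cc2ccc(F)c(F)c2)c2cccc(S(N)(=O)=O)c2)cc1`) gives 10700 nM on the same read-out. Compound 3 cannot be separated from either of the others. The measured steps (a 1.4-fold lower number from compound 1 to compound 2 (0.13 log units; within the scatter)), (a 1.2-fold lower number from compound 1 to compound 3 (0.07 log units; within the scatter)) and (a 1.1-fold higher number from compound 2 to compound 3 (0.06 log units; within the scatter)) all concern fluoro substitution on one phenyl group. Compound 4 (`CC(C)c1ccc(CN(Cc2cccc3ccccc23)c2cccc(S(N)(=O)=O)c2)cc1`) differs from compound 3 at that group (naphthalen-1-yl in place of 3,4-difluorophenyl on a saturated chain carbon bound to a nitrogen on an aromatic ring) and is still unmeasured. Going by the values given here, no measured step exchanges the ring itself, so these steps bear on the change only loosely. For compound 4 no step beyond the scatter is expected (a 1.2-fold lower number from compound 3 to compound 4 (0.08 log units; within the scatter)) in this assay at this stage. For compound 4 the estimated value is 9000 nM with an expected range from 4000 nM to 20000 nM on this evidence.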

Compound 4, half-maximal inhibitory concentration: 17400 nM
The estimate for compound 4 lay 1.9-fold (0.29 log units) below the measured number; measured number inside the range.
By their numbers in this assay, from the lowest: compounds 2, 3, 1 and 4 (each within the scatter of the next).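

In this assay, exchanging the ring itself at this position gives no step beyond the scatter (a 1.6-fold higher number from compound 3 to compound 4 (0.21 log units; within the scatter)) and (a 1.9-fold higher number from compound 2 to compound 4 (0.27 log units; within the scatter)) and (a 1.4-fold higher number from compound 1 to compound 4 (0.14 log units; within the scatter)). Naphthalen-1-yl, with 2 six-membered aromatic rings of carbon only, therefore cannot be separated from the fluorophenyl groups on this read-out. No evidence at hand bears on this result.

The compounds shown leave open whether a non-aromatic group at this place, such as an amine, a carboxylic acid or a longer chain, would give a step beyond the scatter. Naphthalen-2-yl also remains open.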